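The compounds below may be only part of what the source reports. "The series", "measured", "known", "first", "only" and "open" are said of these compounds alone.

Compound 3 `CC(C)(C)c1ccc(-c2cc(N3CCC(CCNS(N)(=O)=O)CC3)ncn2)cc1` carries the higher of the two numbers measured here in a functional assay on HT-29 cells (Homo sapiens) for antiproliferative activity, read by sulforhodamine B assay, with a stated time of 48 h (on this read-out higher numbers stand for weaker inhibition of growth and lower numbers for stronger inhibition of growth), with compound 2 `CC(C)(C)c1ccc(-c2cc(N3CCC(CNS(N)(=O)=O)CC3)ncn2)cc1` the nearest. In this assay compound 3 gives 10300 nM. In this assay compound 2 gives 8900 nM, and the step of a 1.2-fold higher number from compound 2 to compound 3 (0.06 log units; within the scatter) separates the two. Compound 1 `NS(=O)(=O)NCC1CCN(c2cc(-c3ccccc3)ncn2)CC1` reaches only a limit, > 100000 nM in this assay, which is the limit of > 100000 nM in this assay, at which 1 of the 3 values shown sits. Compound 4 `COC(=O)c1ccc(-c2cc(N3CCC(CCNS(N)(=O)=O)CC3)ncn2)cc1` differs from compound 3 by methoxycarbonyl in place of tert-butyl on an aromatic carbon. Within the data shown here, no measured step exchanges one group for another at that position; the only step that bears on it is an at least 11-fold lower number from compound 1 to compound 2 (1.05 log units; beyond the scatter), which removes the tert-butyl entirely and so shows that the group at that place matters a great deal for growth inhibition. An exchange of the tert-butyl for methoxycarbonyl is therefore expected to weaken growth inhibition, though by less than its complete removal did, and the expected step is a 2.9-fold higher number from compound 3 to compound 4 (0.46 log units; beyond the scatter). Compound 4 is accordingly estimated at 30000 nM in this assay, within a range of 9000 nM to 100000 nM.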

Compound 4, concentration for 50% growth inhibition: 19600 nM
Compound 4: the middle estimate sits 1.5-fold (0.18 log units) above what was measured; measured number inside the range.
By their numbers in this assay, from the lowest: compounds 2, 3 and 4 (each within the scatter of the next, the first and the last beyond it). At a limit, above all of these: compound 1.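

In this assay, methoxycarbonyl in place of tert-butyl on the aromatic carbon gives a 1.9-fold higher number from compound 3 to compound 4 (0.28 log units; within the scatter), so this exchange of one four-atom group for another, which brings in two hydrogen-bond acceptors, stays within the scatter. Among these compounds, the earlier compounds showed only what happened when tert-butyl was removed altogether, and on the shorter chain; this step shows that, on the longer chain, tert-butyl is not the only group at this place that gives a number in this range. Nothing measured here gives a reason for this result.

From the compounds shown here alone, it remains open whether a carboxylic acid or an amine at this place would behave like methoxycarbonyl. Going by these compounds, it also remains open whether a chain longer than those in compound 3 and compound 4 would change the number.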